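The source may hold more compounds than are shown below. What is called first, only, known or untested is meant among the compounds shown, and "the series" means these compounds.

Measured so far in a functional assay on Shh Light II cells (Mus musculus) for inhibition, read by a luciferase reporter; on this read-out higher numbers stand for weaker inhibition and lower numbers for stronger inhibition:

Compound 1 `O=C(Nc1ccccc1Cl)N1CCN(c2nc(-c3ccc4ccccc4n3)no2)CC1` gives 140 nM.
Compound 2 `O=C(Nc1ccccc1C(F)(F)F)N1CCC(c2nc(-c3ccc4ccccc4n3)no2)CC1` gives 700 nM.
Compound 3 `N#Cc1ccccc1NC(=O)N1CCC(c2nc(-c3ccc4ccccc4n3)no2)CC1` gives 190 nM.

Compound 1 holds the lowest of the three numbers in this assay, but the value of compound 3 lies within the scatter of it, so the two cannot be ordered; only compound 2 sits clearly apart, with a number beyond the scatter above that of compound 1.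

Compound 4 `O=C(NC1CCCCC1)N1CCN(c2nc(-c3ccc4ccccc4n3)no2)CC1` is not yet measured. Against compound 1 the change is cyclohexyl in place of 2-chlorophenyl on an amide-type nitrogen.

Within the data shown here, the one measured step, a 3.7-fold lower number from compound 2 to compound 3 (0.57 log units; beyond the scatter), swaps one substituent on the aromatic ring for another and keeps the aryl urea; it does not touch the kind of change made here, where the aromatic ring itself is exchanged for a saturated one. Among the measured compounds shown here, nothing among the measured compounds shows what an aliphatic group on the urea nitrogen does in this assay. The expectation is therefore weakly held: a modest rise in the number, a 2.9-fold higher number from compound 1 to compound 4 (0.46 log units; beyond the scatter), with the range kept wide to cover no change at all.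

Compound 4 is estimated at 400 nM, between 120 nM and 1500 nM.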

Compound 4, half-maximal inhibitory concentration in the Shh Light II assay: 53 nM
Estimate against measurement, compound 4: 7.5-fold (0.88 log units) above, and the stated range ends above it.
By their numbers in the Shh Light II assay, from the lowest: compound 4; then compounds 1 and 3 (each within the scatter of the next); then compound 2.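

On the amide-type nitrogen, an aromatic ring is not required for activity: in the Shh Light II assay, cyclohexyl in place of 2-chlorophenyl gives a 2.6-fold lower number from compound 1 to compound 4 (0.42 log units; beyond the scatter), so for this pair a non-aromatic ring of carbon only is accepted and the number improves. In a physicochemical assay for lipophilicity (on this read-out higher numbers stand for higher lipophilicity and lower numbers for lower lipophilicity), compound 1 gives 2.95 and compound 4 gives 2.76, so the two cannot be told apart on this read-out. Nothing available accounts for the step.

Open, as far as these compounds go, is whether cyclohexyl gives a similar step on the core of compound 3. Also open, from the compounds shown here alone, is how far this position tolerates other aliphatic groups, such as a longer alkyl chain or a cyclohexyl ring carrying an amine or a carboxylic acid.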